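The source may hold more compounds than are shown below. What is called first, only, known or untested is meant among the compounds shown, and "the series" means these compounds.

Notes on the series. Compound 1 `CCOC(=O)C(=O)Nc1cccccc1=O` gives 91% in a functional assay on the whole organism (strain Sprague-Dawley CD) for inhibition, with Rattus norvegicus as the target, read by paw edema, at a dose of 100 mg/kg by the oral route; on this read-out lower numbers stand for a weaker effect and higher numbers for a stronger effect at the one dose given. Among the compounds with values here, compound 2 `CCOC(=O)C(=O)Nc1ccccc(Oc2ccccc2)c1=O` gives 9%, the lower of the two numbers so far, with compound 1 the nearest and higher by the one measured step, a number 82 percentage points lower from compound 1 to compound 2 (beyond the scatter). Compound 3 `CCOC(=O)C(=O)Nc1ccccc(Br)c1=O` differs from compound 2 by bromo in place of phenoxy on an aromatic carbon. Within the data shown here, only that one step bears on this change, and it was large, because a number 82 percentage points lower from compound 1 to compound 2 (beyond the scatter) shows the phenoxy group carries a large loss. Bromo is a smaller group than phenoxy, so a partial return toward compound 1 is expected, but the direction is uncertain. Compound 3 is expected to give 50%, range 15% to 85%. This estimate means an expected a number 41 percentage points higher from compound 2 to compound 3 (beyond the scatter).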

Compound 3, a percentage reported as inhibition, in the whole organism at one dose (the size of the read-out at that dose, not a potency): 0%
Beside the measured number, compound 3's estimate is 50 percentage points above it; measured number below the stated range.
By their numbers in this assay, from the lowest: compounds 3 and 2 (each within the scatter of the next); then compound 1.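

Replacing phenoxy with bromo gives a number 9 percentage points lower from compound 2 to compound 3 (within the scatter), so phenoxy, with its aromatic ring, and bromo, with no ring, cannot be told apart at this position. Against hydrogen, bromo gives a number 91 percentage points lower from compound 1 to compound 3 (beyond the scatter), so the large loss is not confined to phenoxy and holds for both groups tested on this aromatic carbon. No evidence on the cause of this loss is at hand.

The compounds shown leave open whether any group other than hydrogen on this carbon keeps the effect, for example fluoro, methyl or an amine.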